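Swapping the sulfonamide heteroaryl once more

The source may hold more compounds than are shown below. What is called first, only, known or untested is meant among the compounds shown, and "the series" means these compounds.

Of the compounds shown here, three sharing one core have been measured in a functional assay on HT-1080 cells (Homo sapiens) for antiproliferative activity, read by sulforhodamine B assay, with a stated time of 48 h; on this read-out higher numbers stand for weaker inhibition and lower numbers for stronger inhibition. Compound 1 `Cc1cc(NS(=O)(=O)c2ccc(N/C(S)=N\c3ccnc4cc(C(F)(F)F)ccc34)cc2)on1` gives 27300 nM. Compound 2 `O=S(=O)(Nc1nccs1)c1ccc(N/C(S)=N\c2ccnc3cc(C(F)(F)F)ccc23)cc1` gives 27300 nM. Compound 3 `O=S(=O)(Nc1ccccn1)c1ccc(N/C(S)=N\c2ccnc3cc(C(F)(F)F)ccc23)cc1` gives 28000 nM. Each of these three differs from the others only in the group carried on the sulfonamide nitrogen, and every step between them is flat: no change at the digits printed from compound 1 to compound 2 (within the scatter), a 1.0-fold higher number from compound 1 to compound 3 (0.01 log units; within the scatter) and a 1.0-fold higher number from compound 2 to compound 3 (0.01 log units; within the scatter). Compound 3 therefore sits among numbers that are all within the scatter of one another.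

Compound 4 `COc1cc(NS(=O)(=O)c2ccc(N/C(S)=N\c3ccnc4cc(C(F)(F)F)ccc34)cc2)nc(OC)n1` has not yet been measured. It differs from compound 3 by 2,6-dimethoxypyrimidin-4-yl in place of pyridin-2-yl on a sulfonamide nitrogen. Among the measured compounds shown here, two of the earlier steps bear directly on this kind of change, since each of them also exchanged one aromatic ring for another on the same sulfonamide nitrogen; both left the number where it was. The ring that enters here carries more hetero atoms and acceptors than the ones tried so far, so the change is a little larger in kind, but nothing measured points to a shift in either direction.

Compound 4 is expected to give 28000 nM, within the range 12000 nM to 65000 nM, a step of no change at the digits printed from compound 3 to compound 4 (within the scatter) beyond the scatter being unexpected.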

Compound 4, half-maximal inhibitory concentration: 29500 nM
The estimate for compound 4 lay 1.1-fold (0.02 log units) below the measured number, within the range that was stated.
By their numbers in this assay, from the lowest: compounds 1, 2, 3 and 4 (each within the scatter of the next).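

In this assay, among the compounds shown here, this sulfonamide nitrogen now shows no response to a bigger exchange than the earlier compounds tested: 2,6-dimethoxypyrimidin-4-yl has more heavy atoms, more ring hetero atoms and more hydrogen-bond acceptors than pyridin-2-yl, yet the result is a 1.1-fold higher number from compound 3 to compound 4 (0.02 log units; within the scatter) and nothing more. The comparisons with the other two rings read the same way, with a 1.1-fold higher number from compound 2 to compound 4 (0.03 log units; within the scatter) and a 1.1-fold higher number from compound 1 to compound 4 (0.03 log units; within the scatter), so the flat picture now covers all four aromatic groups shown, and none of the four goes against it. Why the number stays put despite such a change in the group cannot be said, as no measurement here bears on the reason.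

On these data alone, all four compounds carry an aromatic ring on this nitrogen, so it remains open whether a group of another kind, such as a simple propyl chain or a ring bearing a carboxylic acid or a basic amine, would move the number at all. As far as these compounds go, it is also open whether the same indifference would appear in a different cell line or at a different exposure time.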